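A few compounds are considered here, and "the series" means these few. Any claim that something is new, unique, unknown or untested is made for them only; others in the source may bear on it.

In a functional assay on PC-3 cells (Homo sapiens) for cytotoxicity, read by WST assay, with a stated time of 72 h; a higher number here means a weaker inhibitor, a lower number a stronger inhibitor:
- compound 1 `COc1ccc(C2(c3ccc(O)cc3)C(=O)Nc3c2ccc(F)c3F)cc1`: 2 nM; 2.2 nM; > 1000 nM (3 entries)
- compound 2 `O=C1Nc2c(ccc(F)c2F)C1(c1ccc(O)cc1)C1CCCCCCC1`: > 1000 nM

Within the data shown here, for compound 2, > 1000 nM is a limit of the assay and not a number, and it is the only reading for this compound. The entries for compound 1 do not agree, as two are numbers and one is a limit: the several entries of compound 1 in this assay, 2 nM; 2.2 nM; > 1000 nM (3 entries). The two compounds therefore give only a loose frame, and the limit of > 1000 nM in this assay, at which 1 of the 2 values shown sits, marks how far the data can be read.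

Compound 3 `O=C1Nc2c(ccc(F)c2F)C1(Cc1ccccc1)c1ccc(O)cc1` has benzyl in place of cyclooctyl on a saturated ring carbon. A modest move towards stronger inhibition is expected, written as an at least 2.0-fold lower number from compound 2 to compound 3 (0.30 log units; that floor lies within the scatter), though a second reading that is only a limit would be no surprise. For compound 3 the estimated value is 500 nM, with an expected range of 60 nM to 3000 nM.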

Compound 3, half-maximal inhibitory concentration: > 1000 nM
Compound 3 ended at the assay's limit; the forecaster's own chance of this, stated with the estimate: 45%; at least 2.0-fold (0.30 log units) between middle value and limit.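

Compound 2 and compound 3 both stand at a limit of the assay and not at a number, so benzyl in place of cyclooctyl gives no readable step. Left open is whether these two groups differ at all in cytotoxicity on these cells.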